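Bromo in Place of Chloro on Two Ketone Cores

A few compounds are considered here, and "the series" means these few. Any claim that something is new, unique, unknown or untested is made for them only; others in the source may bear on it.

Compound 1 `O=C1/C(=C/c2ccc(Cl)cc2)Cc2ccccc21` and compound 2 `O=C1/C(=C/c2ccc(Br)cc2)Cc2ccccc21` share one core, while compound 3 `O=C1/C(=C/c2cccc(Cl)c2)CCCc2ccccc21` and compound 4 `O=C1/C(=C/c2cccc(Br)c2)CCCc2ccccc21` share another; the difference between the two cores is not broken down here. In a functional assay on P388 cells (Mus musculus) for inhibition (a higher number here means a weaker inhibitor, a lower number a stronger inhibitor), compound 1 gives only a limit of the assay, > 50000 nM. In this assay compound 2 likewise gives only a limit, > 50000 nM. The change bromo in place of chloro on an aromatic carbon thus yields a step that the two limits leave unreadable from compound 1 to compound 2 because both values sit at the limit of > 50000 nM in this assay, at which 2 of the 3 values shown sit. In this assay compound 3 gives 8200 nM. Compound 4 carries bromo in place of chloro on an aromatic carbon, the same kind of change as that from compound 1 to compound 2, though here the place is meta to a large group rather than para to a large group. With the earlier step unreadable, the expectation rests on compound 3 at 8200 nM and on the small size of the swap, so a step of a 1.0-fold lower number from compound 3 to compound 4 (0.01 log units; within the scatter) is expected. Compound 4 is therefore estimated at 8000 nM, between 3000 nM and 22000 nM.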

Compound 4, half-maximal inhibitory concentration: 10500 nM
For compound 4 the middle estimate is 1.3-fold (0.12 log units) below the measured one; low and high end bracket the measured number.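

In this assay, bromo in place of chloro on an aromatic carbon, meta to a large group, gives a 1.3-fold higher number from compound 3 to compound 4 (0.11 log units; within the scatter), so on this core the two halogens cannot be told apart. The same swap on the core of compound 1 cannot be read, because compound 1 and compound 2 both sit at a limit of the assay: the limit of > 50000 nM in this assay, at which 2 of the 4 values shown sit. The series therefore gives one readable step, which shows nothing about whether the result carries from one core to the other.

From the compounds shown here alone, it remains open how a nitrile, a methoxy group or an amine would read in the place held by the halogen. Also open, going by these compounds, is whether either halogen would read differently at another place on the ring of the core of compound 3.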